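This account rests on a few compounds, and the source may have more. Where it says the series, first, only, none or still open, it means among the compounds named here.

Three measured compounds and one unmeasured compound share a core. Compound 1 `C=C(c1ccc(Cl)cc1Cl)C1COC(C)(C)OO1`, compound 2 `C=C(c1ccc(F)c(F)c1)C1COC2(CCCC2)OO1` and compound 3 `C=C(c1ccc(Cl)c(Cl)c1Cl)C1COC2(CCCCC2)OO1` have each been run in a functional assay on HepG2 cells (Homo sapiens) for inhibition, read by MTT assay, with a stated time of 72 h; on this read-out higher numbers stand for weaker inhibition and lower numbers for stronger inhibition. In this assay compound 1 gives 90500 nM, compound 2 gives 38600 nM and compound 3 gives 9020 nM. Compound 2 thus stands second highest of the three numbers: the number of compound 1 is higher, beyond the scatter, and the number of compound 3 is lower, also beyond the scatter. Compound 4 `C=C(c1ccc(OC)c(F)c1)C1COC2(CCCC2)OO1` has not yet been measured in this assay. It differs from compound 2 in a single place: methoxy in place of fluoro on an aromatic carbon. Within the data shown here, no measured pair in this set shows the same change, so the size of the step is not known from the data; the change is expected to move the number little, and a step in this assay of a 1.3-fold higher number from compound 2 to compound 4 (0.11 log units; within the scatter) is expected, at or just beyond the scatter toward weaker inhibition. For compound 4 in this assay a value of 50000 nM is expected, within a range from 20000 nM to 120000 nM.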

Compound 4, half-maximal inhibitory concentration: 29300 nM
Estimate against measurement, compound 4: 1.7-fold (0.23 log units) above; measured number inside the range.
By their numbers in this assay, from the lowest: compound 3; then compounds 4 and 2 (each within the scatter of the next); then compound 1.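

In this assay methoxy in place of fluoro on an aromatic carbon, ortho to a fluoro group and para to a large group, gives a 1.3-fold lower number from compound 2 to compound 4 (0.12 log units; within the scatter) and so leaves the two numbers within the scatter of each other. Among these compounds, this is the first pair that differs in one place, and it shows that this position accepts the larger methoxy group, with its added hydrogen-bond acceptor, without a change that can be read in this read-out. No measurement at hand bears on the reason for this result.

On these data alone, whether the position stays as undemanding with an amine, a carboxylic acid or a longer alkoxy chain remains open. Also open, as far as these compounds go, is whether the same change gives a similar step on the aromatic ring of compound 1 or compound 3, whose substituents and remaining core differ.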